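The compounds below may be only part of what the source reports. "The series", "measured", "known", "first", "only" and "open" are said of these compounds alone.

Measured compounds:
Compound 1, `C[C@H](Oc1ccc(S(C)(=O)=O)cc1C(=O)N1Cc2ccc(C(F)(F)F)cc2C1)C(F)(F)F`: 21 nM
Compound 2, `C[C@H](Oc1ccc(S(C)(=O)=O)cc1C(=O)N1Cc2ccc(N3CCCC3)cc2C1)C(F)(F)F`: 180 nM
Compound 3, `C[C@H](Oc1ccc(S(C)(=O)=O)cc1C(=O)N1Cc2cc(C(F)(F)F)cnc2C1)C(F)(F)F`: 50 nM

All three share one core and differ only in the group carried on the fused ring. In an assay on CHO cells for inhibition of sodium- and chloride-dependent glycine transporter 1 (Homo sapiens), read by scintillation counting (a lower number here means that less compound is needed, a higher number that more compound is needed for the effect), compound 2 gives 180 nM, the highest number of the three. Compound 3 gives 50 nM, lower than compound 2 by more than the usual scatter, and compound 1 gives 21 nM, lower still. For the measured compounds named here, the one change that can be followed directly is an 8.6-fold higher number from compound 1 to compound 2 (0.93 log units; beyond the scatter), so putting pyrrolidin-1-yl in place of trifluoromethyl raised the number by a modest but clear amount.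

The next compound is compound 4, `C[C@H](Oc1ccc(S(C)(=O)=O)cc1C(=O)N1Cc2ccc(C3CCCCO3)cc2C1)C(F)(F)F`. Its difference from compound 2 is oxan-2-yl in place of pyrrolidin-1-yl on an aromatic carbon. Going by the values given here, no measured pair shows this particular exchange. What the data do show is that the pyrrolidin-1-yl group of compound 2 gave the weakest result here, so replacing it with another small saturated ring, oxan-2-yl, seems more likely to pull the number back toward compound 1 and compound 3 than to push it higher. Compound 4 is therefore expected to give about 80 nM, within 25 nM to 250 nM. The expected step is a 2.3-fold lower number from compound 2 to compound 4 (0.35 log units; beyond the scatter), a modest improvement, though with real uncertainty.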

Compound 4, half-maximal effective concentration: 205 nM
Compound 4: middle estimate off by 2.6-fold (0.41 log units), on the low side, within the range that was stated.
By their numbers in this assay, from the lowest: compound 1; then compound 3; then compounds 2 and 4 (each within the scatter of the next).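

In this assay, exchanging pyrrolidin-1-yl for oxan-2-yl on this aromatic carbon gives a 1.1-fold higher number from compound 2 to compound 4 (0.06 log units; within the scatter), so this assay does not separate the two saturated rings, although one is five-membered with a nitrogen and the other six-membered with an oxygen. Measured against trifluoromethyl, the oxan-2-yl group gives a 9.8-fold higher number from compound 1 to compound 4 (0.99 log units; beyond the scatter), which is close to the earlier 8.6-fold higher number from compound 1 to compound 2 (0.93 log units; beyond the scatter), so at this position both rings stand apart from trifluoromethyl in the same direction and to a similar extent. Nothing available explains why the two rings match or why trifluoromethyl differs from both.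

These compounds leave open whether the higher numbers are tied to having a saturated ring here at all, or simply to losing trifluoromethyl, a question that a chlorine atom, a nitrile or a short open chain such as methoxy on the same carbon could help to settle. They also leave open whether a ring carrying a free amine or a carboxylic acid would follow pyrrolidin-1-yl and oxan-2-yl or break from them.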